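The source may hold more compounds than are shown below. What is called first, only, known or untested is meant among the compounds shown, and "the series" means these compounds.

Measured in a functional assay on HEK293 cells for agonist activity at Bile acid receptor (Homo sapiens), read by a luciferase reporter; a lower number here means a smaller maximal response, a higher number a larger maximal response: compound 1 `CC(C)c1onc(-c2c(Cl)cccc2Cl)c1COc1ccc(N(C)Cc2cccc(C(=O)O)c2)c(C(F)(F)F)n1` gives 58%. Compound 2 `CN(Cc1cccc(C(=O)O)c1)c1ccc(OCc2c(-c3c(Cl)cccc3Cl)noc2C2CC2)nc1C(F)(F)F` gives 43%. Compound 3 `CC(C)c1onc(-c2c(Cl)cccc2Cl)c1COc1cnc(N(C)Cc2ccc(C(=O)O)cc2)c(Cl)c1` gives 51%.

Compound 2 carries the lowest number of the three, although its gap to compound 3 lies within the scatter; only the gap to compound 1 lies beyond it. Going by the values given here, the one measured step, a number 15 percentage points lower from compound 1 to compound 2 (beyond the scatter), came from a cyclopropyl in place of isopropyl on an aromatic carbon. Compound 4 `O=C(O)c1ccc(OCc2ccc(OCc3c(-c4c(Cl)cccc4Cl)noc3C3CC3)nc2C(F)(F)F)cc1` arises from compound 2 by (4-carboxyphenoxy)methyl in place of (3-carboxybenzyl)(methyl)amino on an aromatic carbon. Among the compounds with values here, no measured step touches this change, and the single known step sits elsewhere in the molecule. The step from compound 2 to compound 4 is therefore expected to be small, a number 2 percentage points higher from compound 2 to compound 4 (within the scatter), with no clear direction. Compound 4 is expected to give about 45% in this assay, within 25% to 70%.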

Compound 4, largest response reached (reported as efficacy), in percent of the reference or control that the assay uses: 42%
Compound 4: middle estimate off by 3 percentage points, on the high side; measured number inside the range.
By their numbers in this assay, from the lowest: compounds 4, 2, 3 and 1 (each within the scatter of the next, the first and the last beyond it).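

In this assay, exchanging (3-carboxybenzyl)(methyl)amino for (4-carboxyphenoxy)methyl on this carbon, ortho to a trifluoromethyl group, left the maximal response unchanged: a number 1 percentage points lower from compound 2 to compound 4 (within the scatter). The entering group contains no nitrogen, so in this cyclopropyl series the response does not depend on keeping the nitrogen of the group that left. Nothing measured here explains this result. As far as these compounds go, whether an amide or a longer ether chain at this position would also hold the response remains open, as does whether the same exchange would behave alike with isopropyl instead of cyclopropyl.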